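The compounds below may be only part of what the source reports. "The series", "measured", "known", "first", "only" and "open" are said of these compounds alone.

Measured in a functional assay on HL-60 cells (Homo sapiens) for inhibition, read by MTT assay, with a stated time of 72 h; a lower number here means a stronger inhibitor, a higher number a weaker inhibitor:

compound 1, `CCCCC(=O)N1CCN(c2nnc3nncn3n2)CC1`: 3130 nM
compound 2, `CC(=O)N1CCN(c2nnc3nncn3n2)CC1`: 14700 nM
compound 3, `CN(C)c1nnc2nncn2n1`: 4840 nM

Among these three numbers compound 2 stands highest, so it is the weakest inhibitor of the set; compound 3 sits nearest to it, and compound 1 furthest. The unmeasured compound 4, `CCC(=O)N1CCN(c2nnc3nncn3n2)CC1`, is compound 2 with one change: methyl in place of hydrogen on a saturated chain carbon bound to a carbonyl carbon. For the measured compounds named here, only one measured step speaks to this change. It is the step in the other direction, a 4.7-fold higher number from compound 1 to compound 2 (0.67 log units; beyond the scatter), where the group on that same carbon was propyl and its removal raised the number. Compound 4 brings back a smaller group, methyl, on the same carbon, so a move in the opposite direction, toward a lower number, is expected in this assay, though a smaller one than the propyl step, since methyl is only part of the way to propyl. The expected step is a 2.1-fold lower number from compound 2 to compound 4 (0.32 log units; beyond the scatter). Compound 4 is therefore estimated at 7000 nM, with a range from 3500 nM to 14000 nM.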

Compound 4, half-maximal inhibitory concentration: 10100 nM
For compound 4 the middle estimate is 1.4-fold (0.16 log units) below the measured one; low and high end bracket the measured number.
By their numbers in this assay, from the lowest: compounds 1 and 3 (each within the scatter of the next); then compounds 4 and 2 (each within the scatter of the next).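

In this assay, turning the acetyl group of compound 2 into the propanoyl group of compound 4 gives no change that stands clear of the usual scatter (a 1.5-fold lower number from compound 2 to compound 4 (0.16 log units; within the scatter)). The longer chain of compound 1 still stands apart from compound 4 (a 3.2-fold higher number from compound 1 to compound 4 (0.51 log units; beyond the scatter)), so at this position, a single added methyl is not enough to reach the lower number that compound 1 shows. No measurement shown gives a reason for this.

For the compounds shown here, open is where along the chain the number begins to fall, which the butanoyl chain would help to show, and whether a chain longer than the one in compound 1 lowers it further. Also open, as far as these compounds go, is how a branched group such as isopropyl, a ring such as cyclohexyl or an amine at the chain's end would compare.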